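The compounds below may be only part of what the source reports. "The series", "measured", "known", "first", "only" and "open" are said of these compounds alone.

Measured compounds:
Compound 1, `O=C(O)CCC(=O)N1N=C(c2c(-c3ccccc3)c3cc(Cl)ccc3[nH]c2=O)CC1c1ccc(F)cc1`: 14000 nM
Compound 2, `O=C(O)CCC(=O)N1N=C(c2c(-c3ccc(C(F)(F)F)cc3)c3ccccc3[nH]c2=O)CC1c1ccc(Cl)cc1`: 2800 nM
Compound 3, `O=C(O)CCC(=O)N1N=C(c2c(-c3cccc(C(F)(F)F)c3)c3ccccc3[nH]c2=O)CC1c1ccc(Cl)cc1`: 2600 nM

All three share a core and were tested in an assay on cells (Oocyte) for negative allosteric modulation of glutamate receptor ionotropic, NMDA 2D (Rattus norvegicus), read by two-electrode voltage clamp; a higher number here means a weaker inhibitor, a lower number a stronger inhibitor. Compound 2 stands second highest of the three numbers. Compound 3 lies closest to it, and the two are within the usual scatter of each other; compound 1 gives a higher number than compound 2, and that gap lies beyond the scatter.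

The unmeasured compound 4, `O=C(O)CCC(=O)N1N=C(c2c(-c3cc(Cl)cc(Cl)c3)c3ccccc3[nH]c2=O)CC1c1ccc(Cl)cc1`, differs from compound 2 in one place: 3,5-dichlorophenyl in place of 4-(trifluoromethyl)phenyl on an aromatic carbon. Going by the values given here, the only measured step that bears on this position is the one from compound 2 to compound 3, where the trifluoromethyl group was moved to another carbon of the same aryl ring: a 1.1-fold lower number from compound 2 to compound 3 (0.03 log units; within the scatter). That step shows the aryl substituent pattern has had little effect so far. Among the compounds with values here, compound 4 brings a different substituent, two chlorines, so the comparison is not exact, and no measured pair tests that change directly. A step no larger than the scatter is therefore expected for this assay, with compound 4 estimated near compound 2, at 2200 nM with a range of 700 nM to 7000 nM, which means an expected step of a 1.3-fold lower number from compound 2 to compound 4 (0.10 log units; within the scatter).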

Compound 4, half-maximal inhibitory concentration: 700 nM
Beside the measured number, compound 4's estimate is 3.1-fold (0.50 log units) above it, within the range that was stated.
By their numbers in this assay, from the lowest: compound 4; then compounds 3 and 2 (each within the scatter of the next); then compound 1.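

Moving the trifluoromethyl group around the aryl ring had left the number within the scatter, which made this position look insensitive, but the new aryl group shows that it is not. In this assay, 3,5-dichlorophenyl gives a 4.0-fold lower number from compound 2 to compound 4 (0.60 log units; beyond the scatter), and against the other trifluoromethyl isomer it gives a 3.7-fold lower number from compound 3 to compound 4 (0.57 log units; beyond the scatter), so both steps are modest but lie beyond the scatter. The aryl group on this aromatic carbon can therefore shift the number, even though the first change made there did not, and nothing available explains why this replacement has that effect.

This single replacement alters both the substituent, chlorine for trifluoromethyl, and the pattern on the ring, so the compounds shown cannot separate the contribution of the element from that of the arrangement. Going by these compounds, a phenyl ring with a single chlorine, or one with methyl groups in place of the two chlorines, would be needed to tell these apart, and whether either would match compound 4 remains open.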